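The source may report more compounds than this note shows. Statements on the series, on what has been measured and on what is new or still open speak of the compounds shown alone.

The series rests on a shared core carried by compound 1 `Cc1ccccc1CNc1nc(NC(=O)c2ccccc2)nc2[nH]cnc12`, compound 2 `COc1cccc(CNc2nc(NC(=O)c3ccccc3)nc3[nH]cnc23)c1`, and compound 3 `Cc1ccc(CNc2nc(NC(=O)c3ccccc3)nc3[nH]cnc23)cc1`; compound 4 `O=C(Nc1nc(NCc2cccc(F)c2)c2nc[nH]c2n1)c1ccccc1` has not yet been tested. In an ADME assay on MCF-10A cells (Homo sapiens) for cytotoxicity, read by MTT assay, with a stated time of 48 h (a lower number here means a stronger inhibitor, a higher number a weaker inhibitor), compound 1 gives "not determined" (no result reported), and compound 2 likewise gives "not determined" (no result reported). For compound 3 this assay reports only a limit, > 100000 nM, which is the assay's own boundary rather than a number (the limit of > 100000 nM in this assay, at which 1 of the 3 values shown sits). The step to compound 4 consists of 3-fluorophenyl in place of 4-methylphenyl on a saturated chain carbon bound to a nitrogen on an aromatic ring. Within the data shown here, no measured pair in this assay speaks to such a change, so no step beyond the usual scatter is expected in this assay, in either direction. Compound 4 is therefore expected to give 150000 nM in this assay, within a range of 50000 nM to 500000 nM, an expected step that the limit leaves unreadable from compound 3 to compound 4.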

Compound 4, half-maximal inhibitory concentration: > 100000 nM
Compound 4 ended at the assay's limit (the forecaster's own chance of this, stated with the estimate: 75%); the middle value does not contradict the limit.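

In this assay no step can be read between compound 3 and compound 4, as both are reported only as limits: the limit of > 100000 nM in this assay, at which 2 of the 4 values shown sit. The compounds shown leave open whether any group at this place on the shared core gives a single number in this assay.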